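Cyclopentyl to Benzyl Ether Swap on Two Related Cores

A few compounds are considered here, and "the series" means these few. Any claim that something is new, unique, unknown or untested is made for them only; others in the source may bear on it.

Measured compounds:
Compound 1 `CC(C(=O)NCc1ccc(C(C)(C)C)nc1OC1CCCC1)c1ccc(NS(C)(=O)=O)c(F)c1`: 1.5 nM
Compound 2 `CC(C(=O)NCc1ccc(C(C)(C)C)nc1OCc1ccccc1)c1ccc(NS(C)(=O)=O)c(F)c1`: 4.4 nM
Compound 3 `CC(C(=O)NCc1ccc(C(C)(C)C)cc1OC1CCCC1)c1ccc(NS(C)(=O)=O)c(F)c1`: 1.8 nM

In an assay on cells for antagonist activity at transient receptor potential cation channel subfamily V member 1 (Homo sapiens), read by FLIPR and calcium flux, with a stated time of 6 min (on this read-out lower numbers stand for stronger inhibition and higher numbers for weaker inhibition), compound 1 gives 1.5 nM. Among the compounds with values here, compound 2 carries benzyl in place of cyclopentyl on an oxygen on an aromatic ring, and the step of a 2.9-fold higher number from compound 1 to compound 2 (0.47 log units; beyond the scatter) is the one measured instance of this change. Compound 3 gives 1.8 nM in this assay; its core differs from that of compound 1, but the difference between the two cores is not broken down here. Compound 4 `CC(C(=O)NCc1ccc(C(C)(C)C)cc1OCc1ccccc1)c1ccc(NS(C)(=O)=O)c(F)c1` is not yet measured; it carries benzyl in place of cyclopentyl on an oxygen on an aromatic ring, which is the same change as that from compound 1 to compound 2. Since the values of compound 1 and compound 3 lie within the scatter of one another, the step is expected to carry over in similar size, so for compound 4 a step of a 2.9-fold higher number from compound 3 to compound 4 (0.46 log units; beyond the scatter) is estimated in this assay, because compound 2 showed a 2.9-fold higher number from compound 1 to compound 2 (0.47 log units; beyond the scatter). Compound 4 is therefore expected at 5.2 nM, between 2.5 nM and 11 nM.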

Compound 4, inhibition constant: 2.9 nM
Estimate against measurement, compound 4: 1.8-fold (0.25 log units) above; low and high end bracket the measured number.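

Within the data shown here, on the core of compound 3, benzyl in place of cyclopentyl on the oxygen gives in this assay a 1.6-fold higher number from compound 3 to compound 4 (0.21 log units; within the scatter) and so leaves no step on this core that stands clear of the scatter. Two pairs do not show that the change would keep a fixed size on any further core, and they do not settle whether its size truly depends on the core. Set side by side, the two steps cannot be told apart, so the change carries from one core to the other without a measurable difference: the same change on two cores in this assay, a 2.9-fold higher number (0.47 log units; beyond the scatter) from compound 1 to compound 2 and a 1.6-fold higher number (0.21 log units; within the scatter) from compound 3 to compound 4, 1.8-fold (0.26 log units) apart, within the scatter of two such steps.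

The compounds shown carry only cyclopentyl and benzyl on this oxygen. Going by these compounds, how an amine, a carboxylic acid or a longer alkyl chain at that place would read in this assay remains open.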